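The source may report more compounds than this note shows. Statements on the series, on what has been measured and on what is new or still open speak of the compounds shown alone.

Measured compounds:
compound 1 `COc1ccc(-n2cc(COc3c(/C=C\C(=O)O)ccc(OC)c3CC=C(C)C)nn2)cc1` — "not determined" (no result reported)
compound 2 `COc1ccc(/C=C\C(=O)O)c(OCc2cn(-c3ccc(NC(C)=O)cc3)nn2)c1CC=C(C)C` — 45700 nM
compound 3 `COc1cccc(-n2cc(COc3c(/C=C\C(=O)O)ccc(OC)c3CC=C(C)C)nn2)c1` — 25200 nM

Compound 1 stands nowhere on these numbers: in a functional assay on NCI-H322 cells (Homo sapiens) for cytotoxicity, read by MTT assay, with a stated time of 24 h (a lower number here means a stronger inhibitor, a higher number a weaker inhibitor), compound 1 has no reported value. Compound 4 `COc1ccc(/C=C\C(=O)O)c(OCc2cn(-c3cccc(C#N)c3)nn2)c1CC=C(C)C` differs from compound 1 by 3-cyanophenyl in place of 4-methoxyphenyl on an aromatic nitrogen. Among the measured compounds shown here, no measured step covers 3-cyanophenyl in place of 4-methoxyphenyl. For the measured compounds named here, the only measured step, a 1.8-fold lower number from compound 2 to compound 3 (0.26 log units; within the scatter), also exchanges the group on an aromatic nitrogen, but it lies within the scatter and shows only that both compounds sit in the same weak region. Compound 3, bearing 3-methoxyphenyl, is the closest measured analogue of compound 4. No step beyond the scatter is therefore expected in this assay in either direction. For compound 4 in this assay the estimate is 30000 nM, with a range of 10000 nM to 90000 nM.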

Compound 4, half-maximal inhibitory concentration: 26500 nM
For compound 4 the middle estimate is 1.1-fold (0.05 log units) above the measured one, and the stated range covers the measured number.
By their numbers in this assay, from the lowest: compounds 3, 4 and 2 (each within the scatter of the next).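

In this assay, 3-cyanophenyl on the aromatic nitrogen gives no separation from the earlier aryl groups: a 1.1-fold higher number from compound 3 to compound 4 (0.02 log units; within the scatter), and a 1.7-fold lower number from compound 2 to compound 4 (0.24 log units; within the scatter). Cyano and methoxy on this aromatic carbon thus give values within the scatter of each other, so this change does not separate the compounds. Nothing available explains this flat result.

Compound 1 gives "not determined" (no result reported), so its exchange for 3-cyanophenyl cannot be read. From the compounds shown here alone, whether an amine or a carboxylic acid on the phenyl ring would move the value out of this range remains open.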